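This account rests on a few compounds, and the source may have more. Where it says the series, first, only, none or still open, it means among the compounds named here.

Compound 1 `COc1cc(CC(O)c2ccc(-c3ccc([N+](=O)[O-])cc3)cc2)c([N+](=O)[O-])cc1OC` carries a 4-nitrophenyl group on the shared core. In an ADME assay on HeLa Rh cells (Homo sapiens) for cytotoxicity, read by microscopy (a lower number here means that less compound is tolerated, a higher number that more compound is tolerated), compound 1 gives 21000 nM, the highest number among the three measured compounds. Compound 2 `COc1cc(CC(O)c2ccc(-c3ccc(Br)cc3)cc2)c([N+](=O)[O-])cc1OC` gives 4300 nM in this assay, and compound 3 `COc1cc(CC(O)c2ccc(-c3cccc(F)c3)cc2)c([N+](=O)[O-])cc1OC` gives 7400 nM.

Compound 4 `COc1cc(CC(O)c2ccc(-c3cccc(CO)c3)cc2)c([N+](=O)[O-])cc1OC` has not yet been measured. Compared with compound 1, it differs in one place: 3-(hydroxymethyl)phenyl in place of 4-nitrophenyl on an aromatic carbon.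

Two measured steps start from compound 1 and swap the same 4-nitrophenyl group, so they bear most on this change. Exchanging bromo for nitro gave a 4.9-fold lower number from compound 1 to compound 2 (0.69 log units; beyond the scatter), and putting 3-fluorophenyl in place of 4-nitrophenyl gave a 2.8-fold lower number from compound 1 to compound 3 (0.45 log units; beyond the scatter). Both replacements lowered the number, and the step between compound 2 and compound 3 was a 1.7-fold higher number from compound 2 to compound 3 (0.24 log units; within the scatter). Among the compounds with values here, no measured compound carries a hydroxymethyl group, so the exact size is uncertain, but a modest fall beyond the scatter is expected again.

Compound 4 is therefore expected to give about 9000 nM in this assay, with a range from 4000 nM to 24000 nM. Expressed as a step, that expectation means a 2.3-fold lower number from compound 1 to compound 4 (0.37 log units; beyond the scatter).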

Compound 4, half-maximal cytotoxic concentration: 6000 nM
For compound 4 the middle estimate is 1.5-fold (0.18 log units) above the measured one; the measured number falls inside the stated range.
By their numbers in this assay, from the lowest: compounds 2, 4 and 3 (each within the scatter of the next); then compound 1.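

In this assay, 3-(hydroxymethyl)phenyl is a third replacement for the 4-nitrophenyl group, and it too gives a lower number, with a 3.5-fold lower number from compound 1 to compound 4 (0.54 log units; beyond the scatter), so compound 1 remains apart from all three other compounds. The new group brings a hydrogen-bond donor that the 4-nitrophenyl group lacks, yet this does not separate compound 4 from the halogen-bearing compounds: hydroxymethyl in place of fluoro gives a 1.2-fold lower number from compound 3 to compound 4 (0.09 log units; within the scatter), and the swap from 4-bromophenyl gives a 1.4-fold higher number from compound 2 to compound 4 (0.14 log units; within the scatter), both within the scatter. No measurement is available that would explain why compound 1 stands apart from the other three.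

As far as these compounds go, it remains open whether the higher number of compound 1 depends on the nitro group itself or on where that group sits, a question that a 3-nitrophenyl group would help to answer. Also open, from the compounds shown here alone, is how an amine or a carboxylic acid on the same phenyl ring, or a longer chain in place of hydroxymethyl, would read here, and whether any such group would reach the level of compound 1.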